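The compounds below may be only part of what the source reports. "The series", "measured", "known", "first", "only" and "open" are said of these compounds alone.

For the measured compounds named here, in a functional assay on MDA-MB-231 cells (Homo sapiens) for cytotoxicity, read by MTT assay, with a stated time of 48 h (a lower number here means a stronger inhibitor, a higher number a weaker inhibitor), compound 2 `O=C(/C=C/c1ccc2c(c1)B(O)OC2)c1ccc(F)cc1` gives 1600 nM, the lowest of the two numbers so far; compound 1 `O=C(/C=C/c1ccc2c(c1)B(O)OC2)c1ccco1` gives 7300 nM, and the only measured step is a 4.6-fold lower number from compound 1 to compound 2 (0.66 log units; beyond the scatter). Compound 3 `CCc1ccc(C(=O)/C=C/c2ccc3c(c2)B(O)OC3)cc1` differs from compound 2 by ethyl in place of fluoro on an aromatic carbon. Going by the values given here, that measured step exchanged the group on the carbonyl carbon, not a substituent on the six-membered aromatic ring, so no measured step bears on the present change. The estimated step is no change at the digits printed from compound 2 to compound 3 (within the scatter), expected to lie within the scatter. The estimate for compound 3 is 1600 nM, with an expected range from 500 nM to 5000 nM.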

Compound 3, half-maximal inhibitory concentration: 9800 nM
Compound 3: the middle estimate sits 6.1-fold (0.79 log units) below what was measured, outside the stated range (above it).
By their numbers in this assay, from the lowest: compound 2; then compounds 1 and 3 (each within the scatter of the next).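

In this assay, the substituent on the six-membered aromatic ring, para to a large group, turns out to matter: ethyl in place of fluoro brings a 6.1-fold higher number from compound 2 to compound 3 (0.79 log units; beyond the scatter) and undoes the gain seen with the 4-fluorophenyl group. For the compounds shown here, the earlier step changed only the group on the carbonyl carbon, so this is the first reading of this position. Nothing available explains the step. Going by these compounds, whether chloro, methoxy or an amine at this position would stay close to compound 2 or to compound 3 remains open. So does the number for a plain phenyl group there.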